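Stripping the Oxime Ether: Compound 2 to Compound 4

The source may report more compounds than this note shows. Statements on the series, on what has been measured and on what is new or still open speak of the compounds shown alone.

Compound 1 `COC1(c2cc(F)cc(Sc3ccc4c(c3)CC/C4=N\OCC#N)c2)CCOCC1` gives 30 nM in a functional assay (blood) for inhibition, with Homo sapiens as the target; on this read-out higher numbers stand for weaker inhibition and lower numbers for stronger inhibition.
Compound 2 `C/C(=N\OCc1ccncc1)c1ccc(Sc2cc(F)cc(C3CCOCC3)c2)cc1` gives 300 nM in this assay.
Compound 3 `C/C(=N\O)c1ccccc1Sc1cc(F)cc(C2CCOCC2)c1` reaches only the limit of the assay, > 10000 nM, in this assay; this is a limit and not a number.

Compound 2 stands at the highest of the two numbers; compound 1 sits well lower, a gap that goes beyond the scatter. Compound 4 `C/C(=N\O)c1ccc(Sc2cc(F)cc(C3CCOCC3)c2)cc1` differs from compound 2 by hydrogen in place of (pyridin-4-yl)methyl on an oxygen. Compound 3 also carries a free hydroxy on its oxime, though attached differently, and it sits at the limit (the limit of > 10000 nM in this assay, at which 1 of the 3 values shown sits). The step of a 10-fold higher number from compound 2 to compound 4 (1.00 log units; beyond the scatter) is therefore expected to weaken inhibition beyond the scatter. Compound 4 is estimated at 3000 nM, between 600 nM and 15000 nM.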

Compound 4, half-maximal inhibitory concentration: 80 nM
Compound 4: the middle estimate sits 38-fold (1.57 log units) above what was measured; the measured number lies below the stated range.
By their numbers in this assay, from the lowest: compound 1; then compound 4; then compound 2. At a limit, above all of these: compound 3.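

In this assay, hydrogen in place of (pyridin-4-yl)methyl on this oxygen gives a 3.8-fold lower number from compound 2 to compound 4 (0.57 log units; beyond the scatter) and so strengthens inhibition rather than weakening it. The (pyridin-4-yl)methyl is therefore not needed here for inhibition at this level. A free hydroxy on the oxime does not by itself mark a compound as weak, as compound 4 shows, yet compound 3, which also carries one, stands at a limit and not a number: the limit of > 10000 nM in this assay, at which 1 of the 4 values shown sits.

The compounds shown leave open whether a methyl or a longer chain ending in an amine on this oxygen would lower the number further.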